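A few compounds are considered here, and "the series" means these few. Any claim that something is new, unique, unknown or untested is made for them only; others in the source may bear on it.

Compound 1 `COc1cccc(-c2n[nH]cc2N2CCCNCC2)c1`, compound 2 `COc1ccc(-c2n[nH]cc2N2CCCNCC2)cc1` and compound 3 `COc1cccc(-c2n[nH]cc2N2CCNCC2)c1` share one core and have all been tested in an assay on isolated protein for binding affinity to 5-hydroxytryptamine receptor 4 (Homo sapiens); a lower number here means a stronger inhibitor, a higher number a weaker inhibitor. In this assay compound 1 gives > 10000 nM, which is a limit of the assay rather than a number. Compound 2 likewise reaches only a limit, > 10000 nM. Compound 3 too stands at a limit, > 10000 nM. (the limit of > 10000 nM in this assay, at which 3 of the 3 values shown sit), so no measured step between any two of these compounds can be read off, and none of the three can be called stronger or weaker than another. Compound 4 `Clc1cccc(-c2n[nH]cc2N2CCNCC2)c1` has not yet been tested. It differs from compound 3 by chloro in place of methoxy on an aromatic carbon. Within the data shown here, since every value measured so far sits at the limit, nothing here points in either direction. The expectation for compound 4 is therefore that it also stands at or near the limit, the estimated step that the limit leaves unreadable from compound 3 to compound 4 amounting to nothing beyond scatter. Compound 4 is estimated at 15000 nM, between 3000 nM and 60000 nM, and most likely the assay will again report only a limit.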

Compound 4, inhibition constant: > 10000 nM
Compound 4 gave a limit, no number (the forecaster's own chance of this, stated with the estimate: 75%); the middle value is on the limit's open side.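

In this assay compound 4 gives > 10000 nM and this is a limit. Compound 3 also stands at a limit, so no step can be read between compound 3 and compound 4. Still open, from the compounds shown here alone, is whether any compound with this shared core gives a true number in this assay at all.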